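The source may report more compounds than this note shows. Statements on the series, on what has been measured and on what is new or still open speak of the compounds shown alone.

Measured compounds:
- compound 1 `Cc1cccc(Nc2nccc(-c3cccs3)n2)c1`: 300 nM
- compound 2 `CN(C)c1cccc(Nc2nccc(-c3cccs3)n2)c1`: 2400 nM
- compound 3 `Cc1cc(C)cc(Nc2nccc(-c3cccs3)n2)c1`: 4300 nM

In a functional assay for inhibition, with Homo sapiens as the target (on this read-out lower numbers stand for stronger inhibition and higher numbers for weaker inhibition), compound 1 stands at the lowest of the three numbers. Its nearest neighbour is compound 2, reached by an 8.0-fold higher number from compound 1 to compound 2 (0.90 log units; beyond the scatter); further away is compound 3, reached by a 14-fold higher number from compound 1 to compound 3 (1.16 log units; beyond the scatter). Both changes sit on the ring that carries the methyl, and both moved the number upward beyond the scatter.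

Compound 4 `Cc1cccc(Nc2nccc(-c3ccc(C)s3)n2)c1` differs from compound 1 by methyl in place of hydrogen on an aromatic carbon. Among the compounds with values here, the change reads thiophen-2-yl to 5-methylthiophen-2-yl, on the five-membered ring next to the ring sulfur, a part of the core that none of the measured steps touched. Within the data shown here, the only step of the same kind, a methyl in place of hydrogen, is the step from compound 1 to compound 3, yet it sat on the other ring, so it bears on the new step only loosely. An upward drift of modest size is therefore expected in this assay, with wide uncertainty. Compound 4 is estimated at 600 nM, within 200 nM to 2500 nM, meaning an expected step of a 2.0-fold higher number from compound 1 to compound 4 (0.30 log units; within the scatter).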

Compound 4, half-maximal inhibitory concentration: 1400 nM
The estimate for compound 4 lay 2.3-fold (0.37 log units) below the measured number, within the range that was stated.
By their numbers in this assay, from the lowest: compound 1; then compounds 4, 2 and 3 (each within the scatter of the next, the first and the last beyond it).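

In this assay, the change from thiophen-2-yl to 5-methylthiophen-2-yl gives a 4.7-fold higher number from compound 1 to compound 4 (0.67 log units; beyond the scatter), so the number responds beyond the scatter to a single methyl on the five-membered ring, next to the ring sulfur. The earlier steps shown here touched only the ring that carries the methyl of compound 1; now a methyl in place of hydrogen has raised the number on both rings, the other case being a 14-fold higher number from compound 1 to compound 3 (1.16 log units; beyond the scatter). No supporting information bears on why the number rose here.

The compounds shown leave open whether this rise is specific to methyl or would also follow from a fluorine, a methoxy group or an amine at the same position. They also leave open how a longer chain such as ethyl would read there.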